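Aryl swap on the sulfonamide nitrogen in this series

A few compounds are considered here, and "the series" means these few. Any claim that something is new, unique, unknown or untested is made for them only; others in the source may bear on it.

Measured so far:
compound 1 `O=C(O)CSc1nnc(Br)n1Cc1ccc(Br)c2ccccc12` gives 94 nM in an assay on HEK293 cells for inhibition of solute carrier family 22 member 12 (Homo sapiens); on this read-out lower numbers stand for stronger inhibition and higher numbers for weaker inhibition
compound 2 `O=S(=O)(CSc1nnc(Br)n1Cc1ccc(Br)c2ccccc12)Nc1ccccc1` gives 15800 nM in this assay

Going by the values given here, compound 2 holds the highest of the two numbers in this assay; the only measured step is a 170-fold higher number from compound 1 to compound 2 (2.23 log units; beyond the scatter). Compound 3 `O=S(=O)(CSc1nnc(Br)n1Cc1ccc(Br)c2ccccc12)Nc1cc(Cl)cnc1Cl` differs from compound 2 by 2,5-dichloropyridin-3-yl in place of phenyl on a sulfonamide nitrogen. Among the compounds with values here, the step from compound 1 to compound 2 changed the group on the chain carbon bound to sulfur, not the aryl on the sulfonamide nitrogen, so no measured step bears directly on this change. Without a comparable precedent, no step beyond the scatter is expected in this assay, giving a 1.6-fold lower number from compound 2 to compound 3 (0.20 log units; within the scatter) with a wide range. Compound 3 is therefore estimated at 10000 nM, between 2500 nM and 40000 nM.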

Compound 3, half-maximal inhibitory concentration: 2790 nM
Compound 3: the middle estimate sits 3.6-fold (0.55 log units) above what was measured; low and high end bracket the measured number.
By their numbers in this assay, from the lowest: compound 1; then compound 3; then compound 2.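

In this assay the aryl on the sulfonamide nitrogen alone moves the number: a 5.7-fold lower number from compound 2 to compound 3 (0.75 log units; beyond the scatter) with 2,5-dichloropyridin-3-yl in place of phenyl, a modest step. The earlier step changed only carboxy to phenylsulfamoyl, and compound 3 at 2790 nM still stands above compound 1 at 94 nM on this read-out. No measurement at hand accounts for the step.

Going by these compounds, whether the ring nitrogen or the two chlorines carry the change stays open. A plain pyridin-3-yl or a 2,5-dichlorophenyl on the same nitrogen would separate the two.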